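Adding a methyl two bonds out on the alkyl arm

The source may hold more compounds than are shown below. What is called first, only, known or untested is meant among the compounds shown, and "the series" means these compounds.

Measured in an ADME assay on MT4 cells (Homo sapiens) for cytotoxicity, read by MTT assay, with a stated time of 5 days; on this read-out lower numbers stand for higher toxicity in this test and higher numbers for lower toxicity in this test:
- compound 1, `CN(c1ccnc(Nc2ccc(C#N)cc2)n1)c1c(F)cc(-c2ccc(C#N)cc2)cc1F`, 148000 nM
- compound 2, `CCN(c1ccnc(Nc2ccc(C#N)cc2)n1)c1c(F)cc(-c2ccc(C#N)cc2)cc1F`, 105000 nM
- compound 3, `CC(C)N(c1ccnc(Nc2ccc(C#N)cc2)n1)c1c(F)cc(-c2ccc(C#N)cc2)cc1F`, 172000 nM

Compound 3 stands apart from neither of the other two in this assay: a 1.2-fold higher number from compound 1 to compound 3 (0.07 log units; within the scatter) and a 1.6-fold higher number from compound 2 to compound 3 (0.21 log units; within the scatter). Compound 4, `CCC(C)N(c1ccnc(Nc2ccc(C#N)cc2)n1)c1c(F)cc(-c2ccc(C#N)cc2)cc1F`, differs from compound 3 by methyl in place of hydrogen on a saturated chain carbon, two bonds along the chain from a nitrogen on an aromatic ring, so that isopropyl becomes sec-butyl. The nearest precedents are lengthenings of the same arm one bond closer in: a 1.4-fold lower number from compound 1 to compound 2 (0.15 log units; within the scatter) and a 1.6-fold higher number from compound 2 to compound 3 (0.21 log units; within the scatter). Neither moved the number beyond the scatter, and this assay seems little sensitive to the size of this arm across compounds 1 to 3. Compound 4 is therefore expected to show a 1.1-fold lower number from compound 3 to compound 4 (0.06 log units; within the scatter), no step beyond the scatter. The estimated value of compound 4 in this assay is 150000 nM, within a range of 80000 nM to 300000 nM.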

Compound 4, half-maximal cytotoxic concentration: 217000 nM
Beside the measured number, compound 4's estimate is 1.4-fold (0.16 log units) below it; the range from low to high includes it.
By their numbers in this assay, from the lowest: compounds 2, 1, 3 and 4 (each within the scatter of the next, the first and the last beyond it).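

In this assay, going by these compounds alone, sec-butyl on this nitrogen stands level with isopropyl (a 1.3-fold higher number from compound 3 to compound 4 (0.10 log units; within the scatter)), so a methyl at this place, two bonds along the chain, adds no step of its own. Within the data shown here, the only step beyond the scatter spans the ethyl and sec-butyl arms (a 2.1-fold higher number from compound 2 to compound 4 (0.32 log units; beyond the scatter)), and it is modest, while the methyl and sec-butyl arms stay within it (a 1.5-fold higher number from compound 1 to compound 4 (0.17 log units; within the scatter)). The same methyl change reads alike at both places on the arm: the same change on two cores in this assay, a 1.4-fold lower number (0.15 log units; within the scatter) from compound 1 to compound 2 and a 1.3-fold higher number (0.10 log units; within the scatter) from compound 3 to compound 4, 1.8-fold (0.25 log units) apart, within the scatter of two such steps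

The compounds shown leave open whether a longer chain such as n-hexyl, or an arm ending in an amine or a carboxylic acid, would move this number further.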